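The source may hold more compounds than are shown below. What is called first, only, known or untested is meant among the compounds shown, and "the series" means these compounds.

Measured compounds:
Compound 1 `Ic1ccc(C2CC(c3ccc4c(c3)OCCO4)=NN2c2ccccc2)cc1` — in a functional assay on WM 266-4 cells (Homo sapiens) for antiproliferative activity, read by MTT assay, with a stated time of 24 h (a higher number here means a weaker inhibitor of growth, a lower number a stronger inhibitor of growth), compound 1 gives 3470 nM.
Compound 2 `c1ccc(N2N=C(c3ccc4c(c3)OCCO4)CC2c2ccco2)cc1` — in this assay compound 2 reaches only the assay limit, > 100000 nM.
Compound 3 `Fc1ccc(C2CC(c3ccc4c(c3)OCCO4)=NN2c2ccccc2)cc1` — in this assay compound 3 gives 6050 nM.

Compound 3 and compound 1 lie within the scatter of each other: a 1.7-fold higher number from compound 1 to compound 3 (0.24 log units; within the scatter). Compound 2 sits at the limit (the limit of > 100000 nM in this assay, at which 1 of the 3 values shown sits).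

Compound 4 `Brc1ccc(C2CC(c3ccc4c(c3)OCCO4)=NN2c2ccccc2)cc1` differs from compound 3 by bromo in place of fluoro on an aromatic carbon. Among the measured compounds shown here, the only measured step of the same kind is the halogen exchange a 1.7-fold higher number from compound 1 to compound 3 (0.24 log units; within the scatter), which stayed within the scatter; the steps of an at least 28-fold higher number from compound 1 to compound 2 (1.45 log units; beyond the scatter) and an at least 16-fold lower number from compound 2 to compound 3 (1.21 log units; beyond the scatter) alter a different position and do not bear on this change. A further halogen exchange at this aromatic carbon is therefore expected to give no step beyond the scatter, a 1.3-fold lower number from compound 3 to compound 4 (0.13 log units; within the scatter). Compound 4 is estimated at 4500 nM, range 2200 nM to 9500 nM.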

Compound 4, concentration for 50% growth inhibition: 3010 nM
Estimate against measurement, compound 4: 1.5-fold (0.17 log units) above; the measured number falls inside the stated range.
By their numbers in this assay, from the lowest: compounds 4, 1 and 3 (each within the scatter of the next). At a limit, above all of these: compound 2.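

In this assay bromo in place of fluoro gives a 2.0-fold lower number from compound 3 to compound 4 (0.30 log units; within the scatter) and bromo in place of iodo gives a 1.2-fold lower number from compound 1 to compound 4 (0.06 log units; within the scatter) so fluoro, bromo and iodo on this aromatic carbon cannot be told apart. By contrast, exchanging furan-2-yl for 4-bromophenyl at the saturated ring carbon gives an at least 33-fold lower number from compound 2 to compound 4 (1.52 log units; beyond the scatter) and joins the two earlier large steps at that carbon. Compound 2 stands at a limit, not a number: the limit of > 100000 nM in this assay, at which 1 of the 4 values shown sits.

Open, as far as these compounds go, is whether an amine, a carboxylic acid or a methoxy group on this aromatic carbon would also stay within the scatter.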